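The source may report more compounds than this note shows. Statements on the series, on what has been measured and on what is new or still open speak of the compounds shown alone.

In a functional assay on MOLT-4 cells (Homo sapiens) for inhibition (on this read-out lower numbers stand for stronger inhibition and higher numbers for weaker inhibition), three compounds have values so far:
Compound 1 `O=C1/C(=C/c2ccc(F)cc2)Cc2ccccc21` gives 60000 nM
Compound 2 `O=C1/C(=C/c2cccc(Br)c2)Cc2ccccc21` gives 173000 nM
Compound 3 `Cc1cccc(/C=C2\Cc3ccccc3C2=O)c1` gives 80300 nM

Compound 1 and compound 3 lie within the usual scatter of each other, at the low end of these numbers, while compound 2 gives a number clearly higher than compound 1.

Compound 4 `Cc1ccc(/C=C2\Cc3ccccc3C2=O)cc1` differs from compound 1 by a single change (methyl in place of fluoro on an aromatic carbon), with methyl in place of fluoro on an aromatic carbon. Among the compounds with values here, no measured pair makes this exact swap. Within the data shown here, the one measured step that bears on it (a 2.2-fold lower number from compound 2 to compound 3 (0.33 log units; beyond the scatter)) is modest and also brings in methyl, but it replaces bromo rather than fluoro, so it offers only a loose guide. Compound 3, which also carries methyl, gives 80300 nM and stays within the scatter of compound 1 at 60000 nM on these numbers. A large move in this assay therefore seems unlikely, and the expected step (a 1.2-fold higher number from compound 1 to compound 4 (0.07 log units; within the scatter)) is none beyond the scatter. For compound 4 the expected value is 70000 nM (estimated range 33000 nM to 150000 nM).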

Compound 4, half-maximal inhibitory concentration: > 500000 nM
Compound 4: only a limit was reported; the forecaster's own chance of this, stated with the estimate: 5%; at least 7.1-fold (0.85 log units) between middle value and limit.
By their numbers in this assay, from the lowest: compounds 1 and 3 (each within the scatter of the next); then compound 2. At a limit, above all of these: compound 4.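

In this assay, methyl in place of fluoro at this position, para to a large group, gives an at least 8.3-fold higher number from compound 1 to compound 4 (0.92 log units; beyond the scatter), so one swap of a single heavy atom for another, with no change in hydrogen-bond donors, acceptors or net charge, can move this read-out well beyond the scatter. Compound 3 also carries methyl, at a different place on the same aromatic ring, and gives 80300 nM, so among these compounds the presence of methyl alone does not produce such a jump, and where it sits on the ring appears to matter. Compound 4 is reported only as a limit of the assay, not as a number, so the full size of the step stays unknown: the limit of > 500000 nM in this assay, at which 1 of the 4 values shown sits.

The compounds shown leave open whether this jump is particular to methyl or whether other groups at this position, such as chloro, methoxy or an amine, would give a similarly high number. What lies behind the jump also stays open, as nothing shown here identifies a cause.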